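The source may report more compounds than this note shows. Statements on the series, on what has been measured and on what is new or still open speak of the compounds shown alone.

Measured in a functional assay on DU-145 cells (Homo sapiens) for inhibition, read by trypan blue exclusion, with a stated time of 96 h; a lower number here means a stronger inhibitor of growth, a higher number a weaker inhibitor of growth:
- compound 1 `Cc1cc(C)cc(/C=C(/SCc2ccc(F)cc2)C(=O)c2ccc(Br)cc2)c1`: 10000 nM
- compound 2 `COc1ccccc1/C=C(/SCc1ccc(F)cc1)C(=O)c1ccc(Br)cc1`: 10000 nM
- compound 3 `O=C(/C(=C\c1ccc(O)cc1)SCc1ccc(F)cc1)c1ccc(Br)cc1`: 10000 nM

In this assay compound 3 gives 10000 nM, level with the other two compounds on these numbers. The next step leads to compound 4 `Cc1ccc(C)c(/C=C(/SCc2ccc(F)cc2)C(=O)c2ccc(Br)cc2)c1`, with 2,5-dimethylphenyl in place of 4-hydroxyphenyl on a double-bonded chain carbon bound to a double-bonded chain carbon.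

Three measured steps change this same place: no change at the digits printed from compound 1 to compound 2 (within the scatter), no change at the digits printed from compound 1 to compound 3 (within the scatter) and no change at the digits printed from compound 2 to compound 3 (within the scatter). None of them goes beyond the scatter, so this place has shown no response in the three compounds so far. The nearest measured group is the 3,5-dimethylphenyl of compound 1, at 10000 nM. For the measured compounds named here, no measured compound carries 2,5-dimethylphenyl, so the data give no direct reading for it, and three compounds are a narrow base. The range is therefore kept wide, mainly towards stronger inhibition.

No step beyond the scatter is expected in this assay, and no direction is favoured. The estimated step is no change at the digits printed from compound 3 to compound 4 (within the scatter). For compound 4 the expected value is 10000 nM, with an estimated range from 3000 nM to 15000 nM.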

Compound 4, concentration for 50% growth inhibition: 1000 nM
For compound 4 the middle estimate is 10-fold (1.00 log units) above the measured one, outside the stated range (below it).
By their numbers in this assay, from the lowest: compound 4; then compounds 1, 2 and 3 (each within the scatter of the next).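

In this assay this position, on a double-bonded chain carbon bound to a double-bonded chain carbon, no longer looks silent: 2,5-dimethylphenyl gives a 10-fold lower number from compound 3 to compound 4 (1.00 log units; beyond the scatter) and, against the other two groups, a 10-fold lower number from compound 2 to compound 4 (1.00 log units; beyond the scatter) and a 10-fold lower number from compound 1 to compound 4 (1.00 log units; beyond the scatter). The last of these steps is the most telling, since 3,5-dimethylphenyl and 2,5-dimethylphenyl hold the same atoms and differ only in where the two methyl groups stand on the ring, so the response depends on that arrangement and not merely on the presence of two methyl groups. Nothing available here accounts for the difference between the two arrangements.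

On these data alone, the response rests on compound 4 alone, so it remains open whether a single methyl group, as in 2-methylphenyl, would carry it, or whether 2,5-dichlorophenyl or 2,5-dimethoxyphenyl would behave like 2,5-dimethylphenyl. Also open, as far as these compounds go, is whether the step holds when the 4-fluorobenzyl group on sulfur or the 4-bromophenyl group on the carbonyl gives way to something else, such as a longer chain or a ring bearing an amine.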